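The source may hold more compounds than are shown below. What is called first, only, known or untested is meant among the compounds shown, and "the series" means these compounds.

Measured so far in an assay on membranes from HeLa cells for displacement of a labelled ligand from adenosine receptor A3 (Homo sapiens), read by scintillation counting, with a stated time of 180 min, tested at 1 uM; a higher number here means more inhibition at the concentration tested (going by the name of the read-out), a lower number less inhibition:
compound 1 `CC1=C(C(=O)OC(C)(C)C)C(c2cccs2)NC(=O)N1`: 7%
compound 2 `CC1=C(C(=O)OCc2ccccc2)C(c2cccs2)NC(=O)N1`: 8%
compound 3 `CCSC(=O)C1=C(C)NC(=O)NC1c1cccs1`: 1%

All three numbers sit close together. Compound 3 differs from compound 1 by a number 6 percentage points lower from compound 1 to compound 3 (within the scatter), and the values of compound 3 and compound 2 likewise lie within the scatter of each other, so nothing separates compound 3 from the other two beyond measurement noise.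

The next compound, compound 4 `CC1=C(C(=O)OC2CCC2)C(c2cccs2)NC(=O)N1`, carries a change at the carbonyl carbon: cyclobutyloxy in place of ethylsulfanyl on a carbonyl carbon.

Going by the values given here, two measured steps bear on it. The ethylsulfanyl group was already exchanged against an oxygen-linked group at the same carbonyl carbon, giving a number 6 percentage points lower from compound 1 to compound 3 (within the scatter), and changing the group on that oxygen gave a number 1 percentage points higher from compound 1 to compound 2 (within the scatter). Both are within the scatter. An oxygen-linked group at this position has thus shown no step beyond the scatter whichever alkyl is attached, so no step beyond the scatter in this assay is expected for compound 4 either.

Compound 4 is estimated to give 7%, with a range from 0% to 17%. This estimate corresponds to an expected step of a number 6 percentage points higher from compound 3 to compound 4 (within the scatter).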

Compound 4, a percentage reported as inhibition, at one concentration (the size of the read-out at that concentration, not a potency): 2%
The estimate for compound 4 lay 5 percentage points above the measured number, within the range that was stated.
By their numbers in this assay, from the lowest: compounds 3, 4, 1 and 2 (each within the scatter of the next).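

In this assay a non-aromatic ring now stands on the oxygen at this carbonyl carbon, and cyclobutyloxy in place of ethylsulfanyl gives a number 1 percentage points higher from compound 3 to compound 4 (within the scatter) with no separation between the oxygen-linked and sulfur-linked groups. Cyclobutyl on that oxygen gives a number 6 percentage points lower from compound 2 to compound 4 (within the scatter) when it replaces benzyl and a number 5 percentage points lower from compound 1 to compound 4 (within the scatter) when it replaces tert-butyl, so this four-membered ring is not distinguished from either group. No supporting data bear on why these numbers sit so close together.

As far as these compounds go, whether an amine or a carboxylic acid on this carbonyl carbon, or a longer chain on the oxygen, would give a step beyond the scatter in this assay remains open. From the compounds shown here alone, all four compounds share one core, so the effect of a change elsewhere on it is also open.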